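The compounds below may be only part of what the source reports. "The series", "measured", "known", "first", "only" and "open" are said of these compounds alone.

Measured compounds in an assay on CHO cells for inhibition of sodium channel protein type 2 subunit alpha (Rattus norvegicus); a higher number here means a weaker inhibitor, a lower number a stronger inhibitor:

Compound 1 `CCN(CC)CCCNC(=O)C(c1ccccc1)c1ccccc1` gives 4400 nM.
Compound 2 `CN(CCCNC(=O)C(c1ccccc1)c1ccccc1)Cc1ccccc1` gives 1200 nM.
Compound 3 `CN1CCN(CCCNC(=O)C(c2ccccc2)c2ccccc2)CC1` gives only a limit of the assay, > 200000 nM, and not a number.

All three share the same core and differ only in the amine sitting on a saturated chain carbon, three bonds along the chain from an amide-type nitrogen. Compound 3 stands at the weak end of what has been measured: its result is a limit (the limit of > 200000 nM in this assay, at which 1 of the 3 values shown sits), so it is known only that its inhibition lies at or beyond the reach of this assay.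

The step to compound 4 `O=C(NCCCCN1CCCCC1)C(c1ccccc1)c1ccccc1` makes the change ((piperidin-1-yl)methyl in place of 4-methylpiperazin-1-yl on a saturated chain carbon, three bonds along the chain from an amide-type nitrogen). Going by the values given here, two measured steps bear on it, since both arrive at 4-methylpiperazin-1-yl from another amine: an at least 45-fold higher number from compound 1 to compound 3 (1.65 log units; beyond the scatter) and an at least 160-fold higher number from compound 2 to compound 3 (2.22 log units; beyond the scatter). The change from compound 3 to compound 4 runs the other way, leaving 4-methylpiperazin-1-yl for a different amine, so a large step in the opposite direction is expected, an at least 80-fold lower number from compound 3 to compound 4 (1.90 log units; beyond the scatter). Compound 4 is therefore estimated at 2500 nM, with a range from 600 nM to 12000 nM. The longer chain of compound 4 is tested by neither compound 1 nor compound 2. The range is kept wide.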

Compound 4, half-maximal inhibitory concentration: 10000 nM
For compound 4 the middle estimate is 4.0-fold (0.60 log units) below the measured one; measured number inside the range.
By their numbers in this assay, from the lowest: compound 2; then compound 1; then compound 4. At a limit, above all of these: compound 3.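

In this assay, replacing 4-methylpiperazin-1-yl with (piperidin-1-yl)methyl on a saturated chain carbon, three bonds along the chain from an amide-type nitrogen, brings the series back to a measurable number, with an at least 20-fold lower number from compound 3 to compound 4 (1.30 log units; beyond the scatter), even though both groups hold a six-membered non-aromatic ring and the same count of heavy atoms. The value for compound 3 is still only a limit: the limit of > 200000 nM in this assay, at which 1 of the 4 values shown sits. The recovery is only partial, with an 8.3-fold higher number from compound 2 to compound 4 (0.92 log units; beyond the scatter) and a 2.3-fold higher number from compound 1 to compound 4 (0.36 log units; beyond the scatter), so this ring amine on its longer chain does not match either the benzyl(methyl)amino or the diethylamino group.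

Compound 4 changes the ring and the chain length together, so the compounds shown leave open how much of the difference belongs to each, and a piperidin-1-yl group on the shorter chain of compound 1 would speak to that. Also open, on these data alone, is how other ring amines, such as morpholin-4-yl or pyrrolidin-1-yl, would compare at this place.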